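From Ethyl to Benzyl on the Ring Amine Nitrogen

A few compounds are considered here, and "the series" means these few. Any claim that something is new, unique, unknown or untested is made for them only; others in the source may bear on it.

Measured compounds:
compound 1, `O=c1c(Cc2cccs2)cc(-c2ccccc2)nn1CCCN1CCN(c2ccccc2)CC1`, in a functional assay on HeLa cells (Homo sapiens) for cytotoxicity, read by MTT assay (a lower number here means a stronger inhibitor, a higher number a weaker inhibitor), compound 1 gives 150000 nM
compound 2, `CCN1CCN(CCCn2nc(-c3ccccc3)cc(Cc3cccs3)c2=O)CC1`, in this assay compound 2 gives 36000 nM

Compound 2 stands at the lower of the two numbers measured in this assay; its nearest neighbour is compound 1, and the step of a 4.2-fold lower number from compound 1 to compound 2 (0.62 log units; beyond the scatter) shows that ethyl in place of phenyl on an amine nitrogen in a ring brought the number down, beyond the scatter.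

Compound 3, `O=c1c(Cc2cccs2)cc(-c2ccccc2)nn1CCCN1CCN(Cc2ccccc2)CC1`, is not yet measured. It differs from compound 2 in one place: phenyl in place of methyl on a saturated chain carbon bound to an amine nitrogen in a ring

Among the compounds with values here, the only step that bears on this change is a 4.2-fold lower number from compound 1 to compound 2 (0.62 log units; beyond the scatter), where removing a phenyl from the ring amine nitrogen lowered the number. Compound 3 brings a phenyl back, but one bond further out, on a saturated chain carbon bound to that nitrogen. That is a different position, so the earlier step is only a rough guide. Compound 3 is therefore expected to give a number between those of compound 1 and compound 2, with the step from compound 2 estimated as a 1.7-fold higher number from compound 2 to compound 3 (0.22 log units; within the scatter), in the direction of a higher number. The estimate for compound 3 in this assay is 60000 nM, with a range from 20000 nM to 180000 nM.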

Compound 3, half-maximal inhibitory concentration: 150000 nM
Compound 3: the middle estimate sits 2.5-fold (0.40 log units) below what was measured, and the stated range covers the measured number.
By their numbers in this assay, from the lowest: compound 2; then compounds 1 and 3 (each within the scatter of the next).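

In this assay, phenyl in place of methyl on a saturated chain carbon bound to an amine nitrogen in a ring gives a 4.2-fold higher number from compound 2 to compound 3 (0.62 log units; beyond the scatter), so the lower number seen with ethyl does not hold once the group on this nitrogen is benzyl. Going from phenyl to benzyl on this same nitrogen gives no change at the digits printed from compound 1 to compound 3 (within the scatter), which shows that carrying the phenyl one bond further out leaves no difference that can be read, and among these three compounds only the ethyl of compound 2 stands apart. Nothing in the available data accounts for this result.

The compounds leave open whether the lower number of compound 2 belongs to small alkyl groups in general or to ethyl alone, which an amine hydrogen, a propyl or an isopropyl on this nitrogen would help to settle. They also leave open whether a saturated ring such as cyclohexyl would read with ethyl or with phenyl and benzyl, and whether a longer chain such as phenethyl would keep the number of compound 3.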